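Solubility at neutral pH: cyclobutyl to thiophen-3-yl

A few compounds are considered here, and "the series" means these few. Any claim that something is new, unique, unknown or untested is made for them only; others in the source may bear on it.

Three compounds on the shared core have values in a physicochemical assay for solubility, at pH 7; a lower number here means a less soluble compound, a higher number a more soluble compound. Compound 1 `CC(C)(C)C(=O)N1Cc2c(NC(=O)c3ccncc3)n[nH]c2C1(C)C` gives 205000 nM. Compound 2 `CN1CCC(C(=O)N2Cc3c(NC(=O)C4CCC4)n[nH]c3C2(C)C)CC1` gives only a limit of the assay, > 225000 nM. Compound 3 `CN1CCC(C(=O)N2Cc3c(NC(=O)Nc4cccc(F)c4)n[nH]c3C2(C)C)CC1` likewise gives a limit, > 225000 nM. The step that the two limits leave unreadable from compound 2 to compound 3 therefore cannot be read, since both ends sit at the limit of > 225000 nM in this assay, at which 2 of the 3 values shown sit. Compound 2 thus stands at the limit of this measurement, with one further value beside it at the same limit and compound 1 a little under it.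

Compound 4 `CN1CCC(C(=O)N2Cc3c(NC(=O)c4ccsc4)n[nH]c3C2(C)C)CC1` has not been measured in this assay. It differs from compound 2 in one place: thiophen-3-yl in place of cyclobutyl on a carbonyl carbon. For the measured compounds named here, no measured step exchanges the cyclobutyl on this carbonyl carbon for a ring of that kind, and the only step out of compound 2, the one to compound 3, is of unreadable size. Going by the values given here, with compound 1 at a number and compounds 2 and 3 at the limit, the series so far shows no readable spread in this assay. Compound 4 is therefore expected to stay near the top of the measured range, with a step of an at least 1.1-fold lower number from compound 2 to compound 4 (0.07 log units; that floor lies within the scatter) expected to be small or not readable. The estimate for compound 4 in this assay is 190000 nM, ranging from 90000 nM to 225000 nM.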

Compound 4, solubility: > 225000 nM
Compound 4 gave a limit, no number (the forecaster's own chance of this, stated with the estimate: 45%); middle value at least 1.1-fold (0.07 log units) away from the limit.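

In this assay compound 4 gives > 225000 nM, a limit of the assay and not a number. No step among compound 2, compound 3 and compound 4 can be read, since all three sit at a limit: the limit of > 225000 nM in this assay, at which 3 of the 4 values shown sit.

From the compounds shown here alone, whether cyclobutyl, (3-fluorophenyl)amino and thiophen-3-yl on this carbonyl carbon differ at all in this assay stays open.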